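A few compounds are considered here, and "the series" means these few. Any claim that something is new, unique, unknown or untested is made for them only; others in the source may bear on it.

Compound 1 `N#CC1=C(N)Oc2c(N)cc3nc4ccccc4nc3c2C12C(=O)N(Cc1cnnn1-c1ccc(Cl)cc1)c1ccccc12` gives > 50000 nM in an ADME assay on HUVEC cells (Homo sapiens) for antiproliferative activity, read by MTT assay, with a stated time of 48 h (on this read-out lower numbers stand for stronger inhibition and higher numbers for weaker inhibition), a limit of the assay rather than a number.
Compound 2 `Cc1ccc(Cl)cc1-n1nncc1CN1C(=O)C2(C(C#N)=C(N)Oc3c(N)cc4nc5ccccc5nc4c32)c2ccccc21` gives > 50000 nM in this assay, likewise only a limit.

Going by the values given here, compound 2 therefore stands at the limit, and so does its only neighbour: the step that the two limits leave unreadable from compound 1 to compound 2 cannot be read because both values sit at the limit (the limit of > 50000 nM in this assay, at which 2 of the 2 values shown sit). Compound 3 `Cc1cc(C)c(-n2nncc2CN2C(=O)C3(C(C#N)=C(N)Oc4c(N)cc5nc6ccccc6nc5c43)c3ccccc32)c(C)c1` differs from compound 2 by 2,4,6-trimethylphenyl in place of 5-chloro-2-methylphenyl on an aromatic nitrogen. Among the compounds with values here, no measured step bears on this change in readable size. Compound 3 is therefore expected to report only a limit again, with an estimate of 80000 nM in this assay, between 20000 nM and 300000 nM. The expected step that the limit leaves unreadable from compound 2 to compound 3 thus carries no readable direction.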

Compound 3, half-maximal inhibitory concentration: > 50000 nM
Compound 3 ended at the assay's limit; the forecaster's own chance of this, stated with the estimate: 85%; the middle value lies beyond the limit too.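

Compound 1, compound 2 and compound 3 all sit at one limit, so no step among them can be read: the limit of > 50000 nM in this assay, at which 3 of the 3 values shown sit.

The compounds shown leave open how far each lies beyond that limit in this assay, and whether any other group on the aromatic nitrogen would give a readable value.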